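Swapping an aminophenyl for a dichlorophenyl on a shared core

The source may report more compounds than this note shows. Statements on the series, on what has been measured and on what is new or still open speak of the compounds shown alone.

Measured compounds:
compound 1 `COc1cc(-c2cc(/C=C/C(=O)c3ccc(N)cc3)[nH]n2)cc(OC)c1OC`, 71%
compound 2 `COc1ccc(-c2cc(/C=C/C(=O)c3ccc(OC)c(OC)c3)[nH]n2)cc1`, 61%

Of the compounds shown here, two built on the same core have been measured in a functional assay on UO-31 cells (Homo sapiens) for cytotoxicity, read by sulforhodamine B assay, with a stated time of 48 h, tested at 1 uM; on this read-out lower numbers stand for a stronger effect and higher numbers for a weaker effect at the one concentration tested. Compound 1 gives 71%, the higher of the two numbers. Compound 2 gives 61% in this assay, and the two values lie within the scatter of each other, so nothing can be said about their order. Compound 3 `COc1cc(-c2cc(/C=C/C(=O)c3ccc(Cl)c(Cl)c3)[nH]n2)cc(OC)c1OC` has not yet been measured. It differs from compound 1 at one place: 3,4-dichlorophenyl in place of 4-aminophenyl on a carbonyl carbon. For the measured compounds named here, no measured pair shows what such a change does on this core, so any expectation rests on compound 1 alone. A step of moderate size toward a lower number is expected, a number 9 percentage points lower from compound 1 to compound 3 (within the scatter), though one within the scatter would not surprise. Compound 3 is thus estimated at 62%, between 42% and 86%.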

Compound 3, a percentage reported as activity, at one concentration (the size of the read-out at that concentration, not a potency): 81%
Beside the measured number, compound 3's estimate is 19 percentage points below it; measured number inside the range.
By their numbers in this assay, from the lowest: compounds 2, 1 and 3 (each within the scatter of the next, the first and the last beyond it).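

For the compounds shown here, the first pair on the shared core that differs in one place shows that, in this assay, 3,4-dichlorophenyl in place of 4-aminophenyl on a carbonyl carbon gives a step within the scatter (a number 10 percentage points higher from compound 1 to compound 3 (within the scatter)). At this position, then, a group with one hydrogen-bond donor and one hydrogen-bond acceptor and a group with neither give numbers that cannot be told apart at the one concentration tested. This rests on a single pair, so it describes only these two groups on this core. Going by these compounds, whether a 4-hydroxyphenyl or a 4-carboxyphenyl on the same carbonyl carbon would give a step beyond the scatter remains open, as does whether this pair would read alike at another concentration. Nothing available bears on the reason for this result.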